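The source may report more compounds than this note shows. Statements on the series, on what has been measured and on what is new or still open speak of the compounds shown alone.

Values so far in a functional assay on DU-145 cells (Homo sapiens) for antiproliferative activity, read by MTT assay, with a stated time of 72 h; on this read-out lower numbers stand for stronger inhibition and higher numbers for weaker inhibition
- compound 1 `FC(F)(F)c1ccc(COc2ccc(Nc3ncnc4cc5c(cc34)OCCOCCOCCOCCO5)cc2)cc1` (8800 nM)
- compound 2 `O=[N+]([O-])c1ccc(COc2ccc(Nc3ncnc4cc5c(cc34)OCCOCCOCCOCCO5)cc2)cc1` (> 100000 nM as a limit, not a number)

Compound 2 yields no number and sits at the limit of > 100000 nM in this assay, at which 1 of the 2 values shown sits, in these notes. The next compound, compound 3 `c1ccc(COc2ccc(Nc3ncnc4cc5c(cc34)OCCOCCOCCOCCO5)cc2)cc1`, differs from compound 2 by hydrogen in place of nitro on an aromatic carbon with hydrogen in place of nitro on an aromatic carbon, para to a large group, so that 4-nitrobenzyl becomes benzyl.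

Among the measured compounds shown here, one measured step bears on this change, namely an at least 11-fold higher number from compound 1 to compound 2 (1.05 log units; beyond the scatter) with nitro in place of trifluoromethyl on an aromatic carbon. As far as these compounds go, it is a large step, and its true size remains open on the upper side. For the measured compounds named here, no measured compound yet carries hydrogen at this place, so the step is only an indirect guide. Since nitro is the group carried by compound 2, its loss is expected to move the number down, beyond the scatter, towards the level of compound 1 at 8800 nM without a firm expectation of passing it.

The estimate corresponds to an at least 5.0-fold lower number from compound 2 to compound 3 (0.69 log units; beyond the scatter) as the expected change. In this assay the estimated value for compound 3 is 20000 nM with 5000 nM to 90000 nM as the expected range.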

Compound 3, half-maximal inhibitory concentration: 8800 nM
Compound 3: the middle estimate sits 2.3-fold (0.36 log units) above what was measured; low and high end bracket the measured number.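

In this assay, hydrogen gives this position its unsubstituted reference, and hydrogen in place of trifluoromethyl shows no change at the digits printed from compound 1 to compound 3 (within the scatter). At this place, trifluoromethyl therefore cannot be told apart from having no substituent at all. The removal of nitro shows an at least 11-fold lower number from compound 2 to compound 3 (1.05 log units; beyond the scatter), which places the earlier gap on nitro as the group that stands apart, not on trifluoromethyl as a group that adds to the activity, although the true size of this step stays open on the upper side, as compound 2 carries only a limit and not a number: the limit of > 100000 nM in this assay, at which 1 of the 3 values shown sits.

Among the compounds shown here, with only three groups at this place, it remains open whether the loss is peculiar to nitro or extends to other substituents, and an amine or a nitrile in the same place would show whether the number stays level with compound 1 and compound 3 or moves towards the limit of compound 2. Every compound shown also keeps the benzyloxy group on the same core, so how a simple methoxy in its place would compare remains open.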